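This account rests on a few compounds, and the source may have more. Where it says the series, first, only, none or still open, it means among the compounds named here.

Compound 1: `Cc1cc(C)c(S(=O)(=O)N2CCC(N3CCC(O)CC3)CC2)c(C)c1` — > 5000 nM
Compound 2: `COc1ccccc1-c1ccc(S(=O)(=O)N2CCC(N3CCC(C)CC3)CC2)cc1` — > 5000 nM
Compound 3: `CC1CCN(C2CCN(C(=O)c3ccc(OC(F)(F)F)cc3)CC2)CC1` — > 5000 nM

Of the compounds shown here, three have been measured in an ADME assay on HCT-116 cells (Homo sapiens) for cytotoxicity, read by CellTiter-Glo, with a stated time of 72 h; on this read-out lower numbers stand for stronger inhibition and higher numbers for weaker inhibition. In this assay compound 1 gives > 5000 nM, which is a limit of the assay and not a number. Compound 2 gives > 5000 nM, likewise a limit. Compound 3 gives > 5000 nM, also a limit. Compound 1 therefore stands where every measured compound stands: the limit of > 5000 nM in this assay, at which 3 of the 3 values shown sit. Among the compounds with values here, no step between measured compounds can be drawn from such values. Compound 4, `Cc1ccc(C2CCN(S(=O)(=O)c3c(C)cc(C)cc3C)CC2)cc1`, differs from compound 1 by 4-methylphenyl in place of 4-hydroxypiperidin-1-yl on a saturated ring carbon. Because all three values sit at the limit of > 5000 nM in this assay, at which 3 of the 3 values shown sit, no direction is set for this step in this assay, and a move no larger than the scatter is expected. Compound 4 is estimated at 6000 nM, with a range from 2000 nM to 20000 nM. That estimate means an expected step that the limit leaves unreadable from compound 1 to compound 4.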

Compound 4, half-maximal inhibitory concentration: > 5000 nM
Compound 4: a limit, no number; the forecaster's own chance of this, stated with the estimate: 70%; the middle value is on the limit's open side.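

In this assay, within the data shown here, compound 4 gives > 5000 nM, which is a limit and not a number, so no step from compound 1 to compound 4 can be read. The compounds shown leave open whether any change to the core of compound 1 would give a readable value in this assay.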